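The compounds below may be only part of what the source reports. "The series", "measured", "known", "first", "only" and "open" are said of these compounds alone.

Two compounds sharing one core open the set. Compound 1, `C#Cc1cccc(Nc2ncnc3cc(OCCCCn4ccnc4[N+](=O)[O-])c(OC)cc23)c1`, and compound 2, `C#Cc1cccc(Nc2ncnc3cc(OCCCCCn4ccnc4[N+](=O)[O-])c(OC)cc23)c1`, were both tested in a functional assay on A549 cells (Homo sapiens) for inhibition, read by sulforhodamine B assay, with a stated time of 72 h; on this read-out lower numbers stand for stronger inhibition and higher numbers for weaker inhibition. Compound 1 gives 2210 nM, while compound 2 gives 770 nM. For the measured compounds named here, the single structural change between them is (2-nitro-1H-imidazol-1-yl)methyl in place of 2-nitro-1H-imidazol-1-yl on a saturated chain carbon, four bonds along the chain from an oxygen on an aromatic ring, and it produced a 2.9-fold lower number from compound 1 to compound 2 (0.46 log units; beyond the scatter).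

A third compound, compound 3, `COc1cc2c(Nc3ccc(OCc4cccc(F)c4)c(Cl)c3)ncnc2cc1OCCCCCn1ccnc1[N+](=O)[O-]`, carries a different core; how its core differs from that of compound 1 is not broken down here. In this assay, going by the values given here, compound 3 gives 19900 nM, the highest of the three numbers so far.

The unmeasured compound 4, `COc1cc2c(Nc3ccc(OCc4cccc(F)c4)c(Cl)c3)ncnc2cc1OCCCCCCn1ccnc1[N+](=O)[O-]`, stands to compound 3 as compound 2 stands to compound 1: the change is (2-nitro-1H-imidazol-1-yl)methyl in place of 2-nitro-1H-imidazol-1-yl on a saturated chain carbon, five bonds along the chain from an oxygen on an aromatic ring. The place is not identical word for word, since in compound 1 the group sits four bonds along the chain from an oxygen on an aromatic ring and in compound 3 it sits five bonds along the chain from an oxygen on an aromatic ring, so this is the same kind of change rather than the same change.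

Because the earlier instance gave a 2.9-fold lower number from compound 1 to compound 2 (0.46 log units; beyond the scatter), a step of a similar direction is expected here, worded as a 2.2-fold lower number from compound 3 to compound 4 (0.34 log units; beyond the scatter), though the different core and the longer chain make its size less certain. On that basis compound 4 is expected to give about 9000 nM in this assay, with the estimate spanning from 4000 nM to 25000 nM.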

Compound 4, half-maximal inhibitory concentration: > 50000 nM
Compound 4: no number, only a limit; the forecaster's own chance of this, stated with the estimate: 5%; middle value at least 5.5-fold (0.74 log units) away from the limit.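

In this assay compound 4 gives > 50000 nM, which is a limit of the assay and not a number. For the compounds shown here, putting (2-nitro-1H-imidazol-1-yl)methyl in place of 2-nitro-1H-imidazol-1-yl lowered the number on the core of compound 1 but raised it on the core of compound 3, with an at least 2.5-fold higher number from compound 3 to compound 4 (0.40 log units; beyond the scatter), so the effect of this change did not carry over from one core to the other: the same change on two cores in this assay, a 2.9-fold lower number (0.46 log units; beyond the scatter) from compound 1 to compound 2 and an at least 2.5-fold higher number (0.40 log units; beyond the scatter) from compound 3 to compound 4, at least 7.2-fold (0.85 log units) apart, beyond the scatter of two such steps This rests on only one pair of compounds per core, the change sits at a different place along the chain in each pair, and the step to compound 4 has only a lower bound, so the data neither separate the role of the core from that of the chain position nor give the full size of the step or explain the reversal.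

The compounds shown leave open how the chain of compound 4 would behave on the core of compound 1, and how the chain of compound 1 would behave on the core of compound 3, comparisons that would set the two cores side by side at matching chain lengths. They also leave open whether a longer chain, or an amine in place of the 2-nitro-1H-imidazol-1-yl group, would follow either trend.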